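A few compounds are considered here, and "the series" means these few. Any claim that something is new, unique, unknown or untested is made for them only; others in the source may bear on it.

Working notes on the series. Compound 1 `CC/C(=C\C=C\C(=O)N[C@H](C)CCCc1cccnc1)c1ccc(OC)cc1` carries an ethyl on the double-bonded chain carbon of the core. In a functional assay with platelet-activating factor receptor (Cavia porcellus) as the target (on this read-out higher numbers stand for an effect only at larger amounts of compound and lower numbers for an effect already at smaller amounts), compound 1 gives 0.68 mg/kg; this is the higher of the two numbers in hand, and the gap to the other is within the usual scatter. Compound 2 `COc1ccc(/C(=C\C=C\C(=O)N[C@H](C)CCCc2cccnc2)c2ccccc2)cc1`, with a phenyl at the same position, gives 0.5 mg/kg in this assay; the two values are not distinguishable. Compound 3 `COc1ccc(/C(=C/C=C/C(=O)N[C@H](C)CCCc2cccnc2)C2CCCCC2)cc1` is not yet measured. Relative to compound 1 the change is cyclohexyl in place of ethyl on a double-bonded chain carbon bound to an aromatic carbon and a double-bonded chain carbon. Among the measured compounds shown here, no step between measured compounds describes this change. Since compound 2 shows that a larger group at this carbon sits within the scatter of compound 1, no step beyond the scatter is expected from compound 1 to compound 3, the expected step being a 1.1-fold lower number from compound 1 to compound 3 (0.05 log units; within the scatter). For compound 3 the estimate in this assay is 0.6 mg/kg, with a range from 0.25 mg/kg to 1.5 mg/kg.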

Compound 3, dose for 50% inhibition: 0.21 mg/kg
Beside the measured number, compound 3's estimate is 2.9-fold (0.46 log units) above it; the measured number lies below the stated range.
By their numbers in this assay, from the lowest: compound 3; then compounds 2 and 1 (each within the scatter of the next).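

Among the compounds shown here, the double-bonded chain carbon bound to an aromatic carbon and a double-bonded chain carbon is not indifferent to its substituent in this assay: cyclohexyl in place of ethyl gives a 3.2-fold lower number from compound 1 to compound 3 (0.51 log units; beyond the scatter) and is the first step beyond the scatter at this carbon. Compound 1 and compound 2 alone showed no separation here, so this position can move the read-out, and a six-membered non-aromatic ring of carbon only is compatible with an effect at smaller amounts of compound. Nothing in hand accounts for the step.

Still open, from the compounds shown here alone, is whether the ring itself or the carbon count carries the step; a straight hexyl chain at this carbon would separate the two. Also open, going by these compounds, is how a piperidine ring would read in the same place.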